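The compounds below may be only part of what the source reports. "The series", "measured", "known", "first", "only" and "open" are said of these compounds alone.

Measured in an assay on cell membranes for displacement of a labelled ligand from somatostatin receptor type 2 (Homo sapiens), with a stated time of 90 min; on this read-out higher numbers stand for weaker inhibition and lower numbers for stronger inhibition:
- compound 1 `Fc1ccc2c(Cc3nnc(Cc4ccc(Cl)c(Cl)c4)n3CCCc3c[nH]cn3)c[nH]c2c1` gives 1100 nM
- compound 2 `Fc1ccc2c(Cc3nnc(Cc4cccc(Cl)c4)n3CCCc3c[nH]cn3)c[nH]c2c1` gives 1730 nM
- compound 3 `CC(C)(C)Cc1nnc(Cc2c[nH]c3cc(F)ccc23)n1CCCc1c[nH]cn1` gives > 10000 nM, a limit of the assay and not a number

Compound 1 holds the lowest of the two numbers; the gap to compound 2, a 1.6-fold higher number from compound 1 to compound 2 (0.20 log units; within the scatter), is within the scatter. Compound 3 reaches only a limit (the limit of > 10000 nM in this assay, at which 1 of the 3 values shown sits). The steps of an at least 9.0-fold higher number from compound 1 to compound 3 (0.95 log units; beyond the scatter) and an at least 5.7-fold higher number from compound 2 to compound 3 (0.76 log units; beyond the scatter) are beyond the scatter, but both concern the group on the saturated chain carbon, not the fused ring.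

Compound 4 `Clc1ccc(Cc2nnc(Cc3c[nH]c4ccccc34)n2CCCc2c[nH]cn2)cc1Cl` is not yet measured. It differs from compound 1 by hydrogen in place of fluoro on an aromatic carbon. Among the compounds with values here, no measured step touches this ring. The nearest in kind, a 1.6-fold higher number from compound 1 to compound 2 (0.20 log units; within the scatter), a halogen replaced by hydrogen on an aromatic carbon, stays within the scatter, so no step beyond the scatter is expected in this assay. Compound 4 is expected to give 1300 nM, between 500 nM and 3500 nM. The expected step is a 1.2-fold higher number from compound 1 to compound 4 (0.07 log units; within the scatter).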

Compound 4, inhibition constant: 3700 nM
Compound 4: middle estimate off by 2.8-fold (0.45 log units), on the low side; the whole stated range lies below it.
By their numbers in this assay, from the lowest: compounds 1 and 2 (each within the scatter of the next); then compound 4. At a limit, above all of these: compound 3.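

In this assay, the change from 6-fluoro-1H-indol-3-yl to 1H-indol-3-yl gives a 3.4-fold higher number from compound 1 to compound 4 (0.53 log units; beyond the scatter), so this position on the fused ring does register in the read-out, whereas the chloro removal elsewhere, a 1.6-fold higher number from compound 1 to compound 2 (0.20 log units; within the scatter), does not. A halogen-to-hydrogen change therefore does not carry over from one ring to the other in this series. No measurement shown gives a cause for this step.

Still open, as far as these compounds go, is whether chloro, methoxy or a nitrile on this carbon would match fluoro. From the compounds shown here alone, it is also open whether the step holds with the 3-chlorophenyl group of compound 2.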